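The compounds below may be only part of what the source reports. "The series", "measured", "known", "first", "only" and "open" are said of these compounds alone.

Going by the values given here, compound 2 `CCC(=O)N[C@@H]1CCCc2c1cncc2N1C(=O)c2ccc(Cl)cc2[C@@H]1C` is the one compound of this pair with a number: in an ADME assay on cells for inhibition of cytochrome P450 11B1, mitochondrial (Homo sapiens), read by HTRF (a higher number here means a weaker inhibitor, a lower number a stronger inhibitor), compound 2 gives 414 nM. Compound 1 `CC(=O)N[C@@H]1CCCc2c1cncc2N1C(=O)c2ccc(Cl)cc2[C@@H]1C1CC1` sits at the limit of > 30000 nM in this assay, at which 1 of the 2 values shown sits; in this assay compound 1 gives > 30000 nM, which is a limit and not a number. Among the compounds with values here, no single-change step joins compound 1 and compound 2, so they show only their two values. Compound 3 `CC(=O)N[C@@H]1CCCc2c1cncc2N1C(=O)c2ccc(Cl)cc2[C@@H]1C` differs from compound 2 by hydrogen in place of methyl on a saturated chain carbon bound to a carbonyl carbon. The step from compound 2 to compound 3 is expected to be small, toward weaker inhibition or none beyond the scatter, a 1.7-fold higher number from compound 2 to compound 3 (0.23 log units; within the scatter). Compound 3 is therefore estimated at 700 nM, between 200 nM and 3000 nM.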

Compound 3, half-maximal inhibitory concentration: 81 nM
Compound 3: the middle estimate sits 8.6-fold (0.94 log units) above what was measured, and the stated range ends above it.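

Going from propanoylamino to acetamido moves the number in this assay toward stronger inhibition, with a 5.1-fold lower number from compound 2 to compound 3 (0.71 log units; beyond the scatter), so the methyl on this saturated chain carbon bound to a carbonyl carbon counts against inhibition in this pair. With acetamido held, methyl in place of cyclopropyl on a saturated ring carbon gives an at least 370-fold lower number from compound 1 to compound 3 (2.56 log units; beyond the scatter). That step starts from compound 1, whose value is a limit and not a number: the limit of > 30000 nM in this assay, at which 1 of the 3 values shown sits.

The compounds shown leave open how a longer chain or a formyl group in place of acetyl would read in this assay. They also leave open how an ethyl group or hydrogen would read on the saturated ring carbon that carries methyl in compound 3.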